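Swapping 3-hydroxypiperidin-1-yl for 4-methylpiperazin-1-yl on sulfonyl sulfur

A few compounds are considered here, and "the series" means these few. Any claim that something is new, unique, unknown or untested is made for them only; others in the source may bear on it.

Measured in a functional assay on A2780 cells (Homo sapiens) for cytotoxicity, read by sulforhodamine B assay, with a stated time of 72 h; a higher number here means a weaker inhibitor, a lower number a stronger inhibitor:
- Compound 1 `CCCn1cc(S(=O)(=O)c2ccc(CNC(=O)N3Cc4ccncc4C3)cc2)cn1`: 7.3 nM
- Compound 2 `CCC(=O)N1CCC(S(=O)(=O)c2ccc(CNC(=O)N3Cc4ccncc4C3)cc2)CC1`: 54 nM
- Compound 3 `O=C(NCc1ccc(S(=O)(=O)N2CCC[C@@H](O)C2)cc1)N1Cc2ccncc2C1`: 70 nM

Compound 3 stands level with compound 2 on these numbers, with a 1.3-fold higher number from compound 2 to compound 3 (0.11 log units; within the scatter). Compound 1 lies apart from both, with a 7.4-fold higher number from compound 1 to compound 2 (0.87 log units; beyond the scatter) and a 9.6-fold higher number from compound 1 to compound 3 (0.98 log units; beyond the scatter).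

The next compound is compound 4 `CN1CCN(S(=O)(=O)c2ccc(CNC(=O)N3Cc4ccncc4C3)cc2)CC1`, which carries 4-methylpiperazin-1-yl in place of 3-hydroxypiperidin-1-yl on a sulfonyl sulfur. For the measured compounds named here, no measured step makes this exact exchange. Going by the values given here, the closest is the one between compound 2 and compound 3, where one group with a six-membered non-aromatic ring gives way to another on the same sulfur, and that step, a 1.3-fold higher number from compound 2 to compound 3 (0.11 log units; within the scatter), stayed small. The two larger steps both leave 1-propyl-1H-pyrazol-4-yl, a group that plays no part in the change to compound 4, so they bear on it less. Among the compounds with values here, with only three compounds the evidence is thin, and a step beyond the scatter in this assay is not expected. The expected change is a 1.1-fold higher number from compound 3 to compound 4 (0.06 log units; within the scatter), in effect no shift. For compound 4 the estimated value is 80 nM, with an expected range from 25 nM to 260 nM.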

Compound 4, half-maximal inhibitory concentration: 71 nM
Compound 4: the middle estimate sits 1.1-fold (0.05 log units) above what was measured, and the stated range covers the measured number.
By their numbers in this assay, from the lowest: compound 1; then compounds 2, 3 and 4 (each within the scatter of the next).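

In this assay the exchange on the sulfonyl sulfur leaves the number unmoved, with a 1.0-fold higher number from compound 3 to compound 4 (0.01 log units; within the scatter) even though the hydrogen-bond donor and the defined stereocentre of 3-hydroxypiperidin-1-yl are gone and 4-methylpiperazin-1-yl brings a second hetero atom into the ring. Compound 4 also stands level with the 1-propanoylpiperidin-4-yl compound, with a 1.3-fold higher number from compound 2 to compound 4 (0.12 log units; within the scatter) and so, among the compounds shown, all three groups with a six-membered non-aromatic ring sit together, while 1-propyl-1H-pyrazol-4-yl stays apart, with a 9.7-fold higher number from compound 1 to compound 4 (0.99 log units; beyond the scatter) as the one large step left at this position. Nothing measured on these compounds offers a reason for this flatness.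

The compounds shown leave open whether a morpholin-4-yl group or a piperazin-1-yl group with a free amine hydrogen would join this level on the same sulfur. They also leave open whether the distance of compound 1 from the others goes with its pyrazole ring or with its propyl chain, a question that a 1-methyl-1H-pyrazol-4-yl group or a phenyl group in that place could address.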